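The source may hold more compounds than are shown below. What is called first, only, known or untested is meant among the compounds shown, and "the series" means these compounds.

Measured compounds:
compound 1, `CC1=C(C(=O)OCc2ccccc2)C(c2ccco2)NC(=S)N1`, 4%
compound 2, `COC(=O)C1=C(C)NC(=S)NC1c1cccs1`, 1%
compound 3, `CCCOC(=O)C1=C(C)NC(=S)NC1c1cccs1`, 10%

In an assay on membranes from HeLa cells for displacement of a labelled ligand from adenosine receptor A3 (Homo sapiens), read by scintillation counting, with a stated time of 180 min, tested at 1 uM (on this read-out higher numbers stand for more inhibition at the one concentration tested (going by the name of the read-out) and lower numbers for less inhibition), compound 3 gives the largest of the three numbers, but its gap to compound 1 and its gap to compound 2 are both within the usual scatter, so the three cannot be set apart on these data.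

The step to the unmeasured compound 4, `CC1=C(C(=O)OCc2ccccc2)C(c2cccs2)NC(=S)N1`, is phenyl in place of ethyl on a saturated chain carbon bound to an oxygen next to a carbonyl group. Within the data shown here, the only measured step at this place is a number 9 percentage points higher from compound 2 to compound 3 (within the scatter), which stayed within the scatter. The same benzyl ester as in compound 4 is carried by compound 1, which differs from it elsewhere; in this assay compound 1 gives 4%, again close to the others. Nothing measured here points to a step beyond the scatter for the change to phenyl on the chain carbon at the ester oxygen.

Compound 4 is therefore expected to sit near the other three, with a step of a number 3 percentage points lower from compound 3 to compound 4 (within the scatter) estimated from compound 3. The estimate for compound 4 is 7%, within the range 0% to 20%.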

Compound 4, a percentage reported as inhibition, at one concentration (the size of the read-out at that concentration, not a potency): 24%
The estimate for compound 4 lay 17 percentage points below the measured number, outside the stated range (above it).
By their numbers in this assay, from the lowest: compounds 2, 1 and 3 (each within the scatter of the next); then compound 4.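

In this assay, the place on the saturated chain carbon bound to an oxygen next to a carbonyl group now shows a real response: phenyl in place of ethyl gives a number 14 percentage points higher from compound 3 to compound 4 (beyond the scatter) and phenyl in place of hydrogen gives a number 23 percentage points higher from compound 2 to compound 4 (beyond the scatter), whereas ethyl in place of hydrogen gave only a number 9 percentage points higher from compound 2 to compound 3 (within the scatter) in the same assay. Phenyl at this place is not enough on its own: with that group held constant, thiophen-2-yl in place of furan-2-yl on a saturated ring carbon gives a number 20 percentage points higher from compound 1 to compound 4 (beyond the scatter). The gain therefore depends on the group on the ring carbon as well as on the phenyl.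

As far as these compounds go, whether the phenyl step would hold with furan-2-yl on the ring carbon stays open. So does the effect of a longer chain such as butyl, or of a carboxylic acid on the phenyl.

No evidence at hand bears on the origin of these steps.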